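The source may hold more compounds than are shown below. What is called first, only, known or untested is meant among the compounds shown, and "the series" means these compounds.

Compound 3 `COc1cc(/C=N/Nc2nc(-c3cccc(Br)c3)cs2)cc(Br)c1OC` was tested in a functional assay on Caco-2 cells (Homo sapiens) for inhibition, read by MTT assay, with a stated time of 48 h (on this read-out higher numbers stand for weaker inhibition and lower numbers for stronger inhibition), where compound 3 gives 43400 nM. Compound 2 `COc1cc(/C=N/Nc2nc(-c3ccc(Br)cc3)cs2)cc(Br)c1OC` gives 36200 nM in this assay, and compound 1 `Fc1ccc(/C=N/Nc2nc(-c3cc(C(F)(F)F)cc(C(F)(F)F)c3)cs2)cc1F` gives 62800 nM; on the plain numbers compound 3 holds the second highest of the three, yet each of the other two lies within the scatter of it. Within the data shown here, the only measured step, a 1.2-fold higher number from compound 2 to compound 3 (0.08 log units; within the scatter), is small. Compound 4 `COc1cc(/C=N/Nc2nc(-c3ccc(F)c(F)c3)cs2)cc(Br)c1OC` carries 3,4-difluorophenyl in place of 3-bromophenyl on an aromatic carbon. Among the measured compounds shown here, no measured step swaps a bromine-bearing ring for a fluorine-bearing one, so that single small step is the sole guide. Compound 4 is therefore expected to give 45000 nM, with a range of 20000 nM to 100000 nM, an expected step of a 1.0-fold higher number from compound 3 to compound 4 (0.02 log units; within the scatter) that stays within the scatter.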

Compound 4, half-maximal inhibitory concentration: 21200 nM
For compound 4 the middle estimate is 2.1-fold (0.33 log units) above the measured one; measured number inside the range.
By their numbers in this assay, from the lowest: compounds 4, 2, 3 and 1 (each within the scatter of the next, the first and the last beyond it).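

In this assay the change to 3,4-difluorophenyl from 3-bromophenyl gives a 2.0-fold lower number from compound 3 to compound 4 (0.31 log units; beyond the scatter) on this aromatic carbon of the five-membered ring, so, unlike the earlier bromine shift, this swap shows that the group here can move the number beyond the scatter. Set against 4-bromophenyl, the same group gives a 1.7-fold lower number from compound 2 to compound 4 (0.23 log units; within the scatter) and so holds for only one of the two bromine compounds. No measured evidence explains this difference. As far as these compounds go, whether both fluorines are needed stays open, as does how an amine or a carboxylic acid at this position would read.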